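The source may hold more compounds than are shown below. What is called first, only, known or untested is meant among the compounds shown, and "the series" means these compounds.

Among the compounds with values here, the three measured members share one core. Compound 1 `COc1cc(-c2c(C)nn(-c3nc(-c4ccc(Cl)c(Cl)c4)c(SC(C)C)s3)c2C(=O)O)cc(C(F)(F)F)c1` gives 1380 nM in a functional assay on BJAB cells (Homo sapiens) for antiproliferative activity, with a stated time of 4 days; a higher number here means that more compound is needed for the effect, a lower number that less compound is needed. Compound 2 `Cc1nn(-c2nc(-c3ccc(Cl)c(Cl)c3)c(SC(C)C)s2)c(C(=O)O)c1-c1cnn(C)c1` gives 6800 nM in this assay, and compound 3 `Cc1nn(-c2nc(-c3ccc(Cl)c(Cl)c3)c(SC(C)C)s2)c(C(=O)O)c1-c1cccc(C(F)(F)F)c1` gives 22000 nM, the highest number of the three and beyond the scatter from both of the others. Compound 4 `Cc1nn(-c2nc(-c3ccc(Cl)c(Cl)c3)c(SC(C)C)s2)c(C(=O)O)c1-c1ccccc1[N+](=O)[O-]` carries 2-nitrophenyl in place of 3-(trifluoromethyl)phenyl on an aromatic carbon. Within the data shown here, two steps bear on this site: a 3.2-fold higher number from compound 2 to compound 3 (0.51 log units; beyond the scatter) and a 16-fold higher number from compound 1 to compound 3 (1.20 log units; beyond the scatter). Exchanges of the aryl group here have moved the number by modest to large amounts, and no measured step involves a nitro group, so the direction is open. A modest step is expected, leaning toward a lower number, with compound 4 estimated at 10000 nM (range 3000 nM to 40000 nM), which means an expected 2.2-fold lower number from compound 3 to compound 4 (0.34 log units; beyond the scatter).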

Compound 4, half-maximal effective concentration: 4700 nM
Compound 4: the middle estimate sits 2.1-fold (0.33 log units) above what was measured; the range from low to high includes it.
By their numbers in this assay, from the lowest: compound 1; then compounds 4 and 2 (each within the scatter of the next); then compound 3.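

Exchanging 3-(trifluoromethyl)phenyl for 2-nitrophenyl gives a 4.7-fold lower number from compound 3 to compound 4 (0.67 log units; beyond the scatter) in this assay and shows that an aryl group bearing a nitro group is compatible with this site. The exchange from 1-methyl-1H-pyrazol-4-yl gives a 1.4-fold lower number from compound 2 to compound 4 (0.16 log units; within the scatter) and stays within the scatter, while a 3.4-fold higher number from compound 1 to compound 4 (0.53 log units; beyond the scatter) leaves 3-methoxy-5-(trifluoromethyl)phenyl with the lowest number of the series. No measurement at hand accounts for these shifts.

Still open, from the compounds shown here alone, is whether the nitro group itself or its place on the phenyl ring sets the number. A 2-aminophenyl or 3-nitrophenyl group at this site would separate the two.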